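The compounds below may be only part of what the source reports. "The series", "measured", "known", "first", "only" and "open" are said of these compounds alone.

Measured so far in a functional assay on THP-1 cells (Homo sapiens) for inhibition, read by sulforhodamine B assay, with a stated time of 48 h; a lower number here means a stronger inhibitor, a higher number a weaker inhibitor:
- Compound 1 `COc1ccc(C(O)(Cc2ccc(C)cc2)c2cccc3ccccc23)c(OC)c1OC`: > 20000 nM
- Compound 2 `C=CCC(O)(c1ccc(OC)c(OC)c1OC)c1cccc2ccccc12`: > 20000 nM
- Compound 3 `CCOC(=O)C(C)C(O)(c1ccc(OC)c(OC)c1OC)c1cccc2ccccc12`: > 20000 nM

Compound 3 has only a limit, > 20000 nM, and no actual number. The whole set shares (the limit of > 20000 nM in this assay, at which 3 of the 3 values shown sit).

The change from compound 3 to compound 4 `COc1ccc(C(O)(Cc2ccccc2)c2cccc3ccccc23)c(OC)c1OC` is this: benzyl in place of 1-(ethoxycarbonyl)ethyl on a saturated chain carbon bound to two aromatic carbons and an oxygen on a saturated carbon.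

Two measured steps alter that same carbon and involve the departing group: a step that the two limits leave unreadable from compound 1 to compound 3, and a step that the two limits leave unreadable from compound 2 to compound 3. Neither has a readable size, so they point in no direction. Still, none of the three groups tested on this carbon has yet produced a number in this assay, so no real shift is expected.

The estimated change is a number no higher from compound 3 to compound 4 (the limit leaves the size open).

For compound 4 the estimate is 20000 nM, with an expected range of 8000 nM to 50000 nM, and a report of only a limit is the likeliest outcome.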

Compound 4, half-maximal inhibitory concentration: 12400 nM
Beside the measured number, compound 4's estimate is 1.6-fold (0.21 log units) above it, within the range that was stated.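

In this assay, compound 4 is the only compound shown with a real number rather than a limit, so with benzyl on this carbon the assay gives a reading. Its steps from the other compounds are an at least 1.6-fold lower number from compound 3 to compound 4 (0.20 log units; that floor lies within the scatter), an at least 1.6-fold lower number from compound 2 to compound 4 (0.20 log units; that floor lies within the scatter) and an at least 1.6-fold lower number from compound 1 to compound 4 (0.20 log units; that floor lies within the scatter); each is only a floor and the true size may be larger, because the other compound in each step sits at a limit: the limit of > 20000 nM in this assay, at which 3 of the 4 values shown sit. The last of these steps is just hydrogen in place of methyl on an aromatic carbon, yet it links a limit to a number.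

On these data alone, how far compound 1, compound 2 and compound 3 truly lie from compound 4 stays open. Also open, as far as these compounds go, is whether an aminomethyl group or a longer chain such as phenethyl in place of benzyl on this carbon would give a lower number.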